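The source may report more compounds than this note shows. Statements on the series, on what has been measured and on what is new or still open speak of the compounds shown alone.

Measured so far:

Compound 1, `COc1cnc(-n2cc(C)cn2)c2[nH]cc(C(=O)C(=O)N3CCN(C(=O)c4ccccc4)CC3)c12`, in a functional assay on MT2 cells (Homo sapiens) for cytotoxicity, read by XTT assay, with a stated time of 3 days (on this read-out lower numbers stand for higher toxicity in this test and higher numbers for lower toxicity in this test), compound 1 gives 243000 nM.
Compound 2, `COc1cnc(-n2cnc(N3CCN(C)CC3)n2)c2[nH]cc(C(=O)C(=O)N3CCN(C(=O)c4ccccc4)CC3)c12`. For compound 2 only a limit of the assay is recorded, > 300000 nM.
Compound 3, `COc1cnc(-n2cnc(C(=O)N3CCN(C)CC3)n2)c2[nH]cc(C(=O)C(=O)N3CCN(C(=O)c4ccccc4)CC3)c12`. For compound 3 likewise only a limit is recorded, > 150000 nM.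

Compound 3 therefore stands at one of the two limits in this series, (the limit of > 150000 nM in this assay, at which 1 of the 3 values shown sits), while compound 2 sits at the other, (the limit of > 300000 nM in this assay, at which 1 of the 3 values shown sits). Of the three compounds only compound 1 has a full number. The step of an at least 1.2-fold higher number from compound 1 to compound 2 (0.09 log units; that floor lies within the scatter) is the only one with a readable size, and its floor lies within the scatter. The step that the two limits leave unreadable from compound 2 to compound 3 cannot be read at all.

Compound 4, `COc1ncn(-c2ncc(OC)c3c(C(=O)C(=O)N4CCN(C(=O)c5ccccc5)CC4)c[nH]c23)n1`, is the next compound in this assay. It differs from compound 3 by methoxy in place of (4-methylpiperazin-1-yl)carbonyl on an aromatic carbon. Within the data shown here, no measured step touches this exact change, so the expectation rests on the general picture: every value so far lies at or near the upper end of the measured range, and the only readable step is within the scatter. Compound 4 is therefore expected to show no change beyond the scatter, a step that the limit leaves unreadable from compound 3 to compound 4. The estimate for compound 4 is 200000 nM, with a range from 90000 nM to 450000 nM, and a limit rather than a number is considered likely.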

Compound 4, half-maximal cytotoxic concentration: 285000 nM
Compound 4: the middle estimate sits 1.4-fold (0.15 log units) below what was measured; the measured number falls inside the stated range.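

Among these compounds, with methoxy on the aromatic carbon of the five-membered aromatic ring with 3 nitrogen, compound 4 gives the first full number among the compounds carrying that ring, where compound 2 and compound 3 offer only limits. In this assay, methoxy in place of 4-methylpiperazin-1-yl gives an at least 1.0-fold lower number from compound 2 to compound 4 (0.02 log units; that floor lies within the scatter), and 3-methoxy-1H-1,2,4-triazol-1-yl in place of 4-methyl-1H-pyrazol-1-yl gives a 1.2-fold higher number from compound 1 to compound 4 (0.07 log units; within the scatter), so the first step offers only a floor and the second shows that this exchange of the whole group stays within the scatter. The step from compound 3 to compound 4 cannot be read because compound 3 stands at a limit: the limit of > 150000 nM in this assay, at which 1 of the 4 values shown sits.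

On these data alone, whether a primary amine, a carboxylic acid or a longer chain such as ethoxy on this aromatic carbon would move the number beyond the scatter in this assay stays open. All four compounds share the same core, so the compounds shown also leave open how far a change elsewhere in the core would shift this read-out.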